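The compounds below may be only part of what the source reports. "The series", "measured", "known", "first", "only" and "open" are said of these compounds alone.

Measured so far in an ADME assay on MCF-10A cells (Homo sapiens) for cytotoxicity, read by MTT assay, with a stated time of 24 h; on this read-out higher numbers stand for weaker inhibition and lower numbers for stronger inhibition:
Compound 1 `FC(F)(F)C(F)(F)C(F)(F)C(F)(F)C(F)(F)C(F)(F)CCn1cc(COc2ccccc2-c2nc3ccccc3s2)nn1`; in this assay compound 1 gives 35100 nM.
Compound 2 `FC(F)(F)Oc1ccc(-c2cc(COc3ccccc3-c3nc4ccccc4s3)on2)cc1`; in this assay compound 2 gives 43900 nM.

Compound 2 and compound 1 share the same core and differ only in the group attached to it. Their two numbers in this assay lie within the scatter of each other, so on these data nothing separates compound 2 from compound 1, and neither can be called the weaker or the stronger of the pair.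

Compound 3 `Brc1ccc(-c2cc(COc3ccccc3-c3nc4ccccc4s3)on2)cc1` is not yet measured. It differs from compound 2 in one place: bromo in place of trifluoromethoxy on an aromatic carbon. Among the compounds with values here, no step between measured compounds covers this change, so its size in this assay has no direct anchor. The two numbers to hand sit close together although the attached groups differ considerably, which gives no ground to expect a step beyond the scatter. For compound 3 the expected step is a 1.1-fold lower number from compound 2 to compound 3 (0.04 log units; within the scatter), essentially none. Compound 3 is estimated at 40000 nM in this assay, with a range from 15000 nM to 100000 nM.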

Compound 3, half-maximal inhibitory concentration: 29200 nM
For compound 3 the middle estimate is 1.4-fold (0.14 log units) above the measured one, within the range that was stated.
By their numbers in this assay, from the lowest: compounds 3, 1 and 2 (each within the scatter of the next).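

In this assay, within the data shown here, the change from 4-(trifluoromethoxy)phenyl to 4-bromophenyl gives the first step that can be read at this position: a 1.5-fold lower number from compound 2 to compound 3 (0.18 log units; within the scatter). On an aromatic carbon para to a large group, trifluoromethoxy, with 5 heavy atoms and 1 hydrogen-bond acceptor, can thus give way to bromo, with 1 heavy atom and no hydrogen-bond acceptor, without a step beyond the scatter on this read-out, and this holds for this one pair only. Nothing at hand bears on why the two numbers stay within the scatter of each other.

On these data alone, it remains open whether any group at this position gives a step beyond the scatter, as the two groups compared here both carry no hydrogen-bond donor and no net charge, so an amine or a carboxylic acid on the same carbon would be a more demanding test. Also open, as far as these compounds go, is whether the change from trifluoromethoxy to bromo gives a similar step when the rest of the molecule differs, which this single pair cannot show.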